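Swapping a fluoro for an ethoxycarbonyl on the aryl ring

The source may report more compounds than this note shows. Statements on the series, on what has been measured and on what is new or still open speak of the compounds shown alone.

Measured so far in a functional assay on HCT-116 cells (Homo sapiens) for inhibition, read by CCK-8 assay, with a stated time of 48 h; a higher number here means a weaker inhibitor, a lower number a stronger inhibitor:
compound 1, `COc1cc(-c2ccnc3cc(-c4ccc(F)cc4)nn23)cc(OC)c1OC`, gives 5030 nM;
compound 2, `COc1cc(-c2ccnc3cc(-c4c[nH]c5ccccc45)nn23)cc(OC)c1OC`, gives 35 nM;
compound 3, `COc1cc(-c2ccnc3cc(-c4ccc5cnn(C)c5c4)nn23)cc(OC)c1OC`, gives 2440 nM.

Compound 1 stands at the highest of the three numbers, so it is the weakest inhibitor of the set. Its nearest neighbour is compound 3, reached by a 2.1-fold lower number from compound 1 to compound 3 (0.31 log units; beyond the scatter); the furthest is compound 2, reached by a 140-fold lower number from compound 1 to compound 2 (2.16 log units; beyond the scatter). Between the two bicyclic compounds lies a 70-fold higher number from compound 2 to compound 3 (1.84 log units; beyond the scatter).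

The new compound, compound 4, `CCOC(=O)c1ccc(-c2cc3nccc(-c4cc(OC)c(OC)c(OC)c4)n3n2)cc1`, keeps the shared core and the six-membered aromatic ring of carbon only, and changes one thing: ethoxycarbonyl in place of fluoro on an aromatic carbon. This is a different kind of change from those measured: both known steps from compound 1 replace the whole 4-fluorophenyl with a bicyclic group, whereas here the ring stays and only its substituent changes. Going by the values given here, no measured pair speaks to this swap, so the size and direction of the step from compound 1 to compound 4 in this assay are open; a modest move in either direction, or none beyond the scatter, is the most defensible expectation.

Compound 4 is therefore estimated at 4000 nM, within 1000 nM to 16000 nM, which means an expected step of a 1.3-fold lower number from compound 1 to compound 4 (0.10 log units; within the scatter).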

Compound 4, half-maximal inhibitory concentration: > 10000 nM
Compound 4: no number, only a limit; the forecaster's own chance of this, stated with the estimate: 10%; middle value at least 2.5-fold (0.39 log units) away from the limit.
By their numbers in this assay, from the lowest: compound 2; then compound 3; then compound 1. At a limit, above all of these: compound 4.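

In this assay compound 4 gives > 10000 nM, a limit of the assay and not a number: the limit of > 10000 nM in this assay, at which 1 of the 4 values shown sits. Among the compounds shown, this is the only case in which the six-membered aromatic ring of carbon only stays in place and just its substituent changes, and ethoxycarbonyl in place of fluoro gives an at least 1.9-fold higher number from compound 1 to compound 4 (0.29 log units; that floor lies within the scatter). The true gap may be larger, but its floor alone does not separate the two compounds; what the result does show is that this swap brought no sign of the large gain seen when the whole 4-fluorophenyl gave way to 1H-indol-3-yl, a 140-fold lower number from compound 1 to compound 2 (2.16 log units; beyond the scatter).

From the compounds shown here alone, how far the true value of compound 4 lies past its limit stays open, so the size of this step cannot be read beyond its floor. Also open, going by these compounds, is whether a different group at this place, para to a large group, such as a carboxylic acid, an amide or an amine, would move the number in either direction, since a single ester sets no trend across substituents.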